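From 4-methoxy-2-nitrophenyl to 2-ethylphenyl in compound 3

The compounds below may be only part of what the source reports. "The series", "measured", "known", "first", "only" and "open" are said of these compounds alone.

Measured in a functional assay on MCF7 cells (Homo sapiens) for antiproliferative activity, read by MTT assay; a higher number here means a weaker inhibitor, a lower number a stronger inhibitor
Compound 1 `Cc1c(-n2cc(COc3ccc(/C=C/C(=O)c4cc5c(cc4O)OC(C)(C)CC5)cc3)nn2)cccc1[N+](=O)[O-]` gives 176000 nM
Compound 2 `COc1ccc(-n2cc(COc3ccc(/C=C/C(=O)c4cc5c(cc4O)OC(C)(C)CC5)cc3)nn2)c([N+](=O)[O-])c1` gives "not active" (no number reported)

Compound 2 has no single number in this assay and is reported only as ("not active" (no number reported)), so it cannot be placed on the scale. Compound 3 `CCc1ccccc1-n1cc(COc2ccc(/C=C/C(=O)c3cc4c(cc3O)OC(C)(C)CC4)cc2)nn1` differs from it (2-ethylphenyl in place of 4-methoxy-2-nitrophenyl on an aromatic nitrogen), with 2-ethylphenyl in place of 4-methoxy-2-nitrophenyl on an aromatic nitrogen. Among the measured compounds shown here, no measured pair gives the size of this step. For the measured compounds named here, a modest step toward stronger inhibition, reaching a measurable but weak value, is expected, with compound 1 (176000 nM) as the only numerical guide. For compound 3 the expected value is 100000 nM (estimated range 30000 nM to 300000 nM).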

Compound 3, half-maximal inhibitory concentration: "not active" (no number reported)
For compound 3 the study gives words and no number; the estimate stays without a comparison.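

In this assay, among the compounds shown here, compound 2 and compound 3 are both reported without a number, so no step between them can be read. Nothing available bears on this result. The compounds shown leave open whether 2-ethylphenyl and 4-methoxy-2-nitrophenyl differ in effect at all.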